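This account rests on a few compounds, and the source may have more. Where it says the series, first, only, none or still open, it means among the compounds named here.

Values from a physicochemical assay for solubility, at pH 6.8 (on this read-out lower numbers stand for lower solubility and higher numbers for higher solubility), so far:
- Compound 1 `CCNC(=O)c1nc(-c2ccc(CN(C)C)cc2)cnc1N` gives > 1000000 nM (a limit, not a number)
- Compound 2 `CCN(CC)Cc1ccc(-c2cnc(N)c(C(=O)NC[C@@](C)(O)C(F)(F)F)n2)cc1` gives > 1000000 nM (a limit, not a number)

Compound 1 has no exact reading, only a limit. The position of compound 1 is described by the limit of > 1000000 nM in this assay, at which 2 of the 2 values shown sit, and by nothing finer. Going by the values given here, with both readings at a limit, no measured step is available to serve as a guide.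

Compound 3 `CC(O)CNC(=O)c1nc(-c2ccc(CN(C)C)cc2)cnc1N` has not yet been measured. The difference 1-hydroxyethyl in place of methyl on a saturated chain carbon bound to an amide-type nitrogen puts 1-hydroxyethyl in place of methyl on a saturated chain carbon bound to an amide-type nitrogen. The same difference, cut one bond further out, reads ethyl to 2-hydroxypropyl.

The expectation rests on compound 1, which gives > 1000000 nM as its limit. No step beyond the scatter is expected in this assay and no direction can be argued. The expected step of a number no higher from compound 1 to compound 3 (the limit leaves the size open) is therefore small, and most likely the reading will again be only a limit. Compound 3 is estimated at 1000000 nM with an expected range from 500000 nM to 2000000 nM in this assay once tested.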

Compound 3, solubility: > 1000000 nM
Compound 3 was reported as a limit; the forecaster's own chance of this, stated with the estimate: 85%; the middle value sits exactly at the limit.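

No step can be read from compound 1 to compound 3, because both readings are limits and not numbers: the limit of > 1000000 nM in this assay, at which 3 of the 3 values shown sit. The compounds shown leave open whether 2-hydroxypropyl in place of ethyl changes the reading at all, since no exact value is available for any of them.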